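Aryl variation on the hydrazone end of the shared core

A few compounds are considered here, and "the series" means these few. Any claim that something is new, unique, unknown or untested is made for them only; others in the source may bear on it.

Measured compounds in a functional assay on HT-29 cells (Homo sapiens) for cytotoxicity, read by MTT assay, with a stated time of 72 h; on this read-out lower numbers stand for stronger inhibition and higher numbers for weaker inhibition:
compound 1 `CN(C)CCn1cnnc1-c1cc(Oc2ccc(NC(=O)N/N=C/c3cccc(Br)c3)cc2F)ccn1`: 380 nM
compound 2 `CN(C)CCn1cnnc1-c1cc(Oc2ccc(NC(=O)N/N=C/c3cc(Br)c(O)c(Br)c3)cc2F)ccn1`: 2670 nM
compound 3 `CN(C)CCn1cnnc1-c1cc(Oc2ccc(NC(=O)N/N=C/c3ccc(F)cc3F)cc2F)ccn1`: 960 nM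

Compound 1 gives the lowest number of the three in this assay. Compound 3 stands nearest, with a 2.5-fold higher number from compound 1 to compound 3 (0.40 log units; beyond the scatter), and compound 2 furthest, with a 7.0-fold higher number from compound 1 to compound 2 (0.85 log units; beyond the scatter). Between those two, a 2.8-fold lower number from compound 2 to compound 3 (0.44 log units; beyond the scatter).

Compound 4 `CN(C)CCn1cnnc1-c1cc(Oc2ccc(NC(=O)N/N=C/c3ccc(O)cc3O)cc2F)ccn1` has not yet been measured. It differs from compound 1 in one place: 2,4-dihydroxyphenyl in place of 3-bromophenyl on a carbon with a double bond to nitrogen. Both measured steps away from compound 1 change the same aryl group on the carbon double-bonded to nitrogen, and both raise the number: a 7.0-fold higher number from compound 1 to compound 2 (0.85 log units; beyond the scatter) and a 2.5-fold higher number from compound 1 to compound 3 (0.40 log units; beyond the scatter). The change to compound 4 touches the same position, and the entering 2,4-dihydroxyphenyl shares a hydroxyl with the 3,5-dibromo-4-hydroxyphenyl of compound 2, the group that gave the larger rise. A rise beyond the scatter is therefore expected, roughly between the two measured steps; the expected step is a 3.9-fold higher number from compound 1 to compound 4 (0.60 log units; beyond the scatter). Compound 4 is expected to give about 1500 nM, with a range of 500 nM to 4500 nM.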

Compound 4, half-maximal inhibitory concentration: 52600 nM
Compound 4: the middle estimate sits 35-fold (1.54 log units) below what was measured, and the stated range ends below it.
By their numbers in this assay, from the lowest: compound 1; then compound 3; then compound 2; then compound 4.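

In this assay, the hydrazone aryl position proves far less tolerant than the first three compounds indicated: 2,4-dihydroxyphenyl in place of 3-bromophenyl gives a 140-fold higher number from compound 1 to compound 4 (2.14 log units; beyond the scatter), a much larger step than either earlier change from compound 1. The rise is not explained by the substitution pattern of the ring alone or by the mere presence of a hydroxyl: swapping 2,4-difluorophenyl for 2,4-dihydroxyphenyl gives a 55-fold higher number from compound 3 to compound 4 (1.74 log units; beyond the scatter), while compound 2, whose aryl group also carries a hydroxyl, is still separated from the new compound by a 20-fold higher number from compound 2 to compound 4 (1.29 log units; beyond the scatter). No measurement in hand accounts for the size of these steps.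

The compounds shown leave open whether the loss needs both hydroxyls or follows from one of them, a question that 2-hydroxyphenyl and 4-hydroxyphenyl analogues would address. They also leave open whether the free hydroxyl hydrogens matter, which a 2,4-dimethoxyphenyl group would test, and whether an amine or a carboxylic acid on this aryl ring would fall as steeply.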